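Isobutyl in place of 3-(dimethylamino)phenoxy: working notes

The compounds below may be only part of what the source reports. "The series", "measured", "known", "first", "only" and "open" are said of these compounds alone.

Measured in an ADME assay for permeability, using PAMPA, with a stated time of 30 min, at pH 7.4; a higher number here means that the compound crosses the layer faster, a lower number that the compound crosses the layer more slowly:
- compound 1 `CC(C)Cc1ccc2c(NCCCNCc3ccco3)ccnc2c1`: 23 10^-6 cm/s
- compound 2 `COc1cccc(Oc2ccc3c(NCCCNCc4cccc(OC)c4O)ccnc3c2)c1`: 317 10^-6 cm/s
- compound 3 `COc1cccc(CNCCCNc2ccnc3cc(Oc4cccc(N(C)C)c4)ccc23)c1O`: 317 10^-6 cm/s

Compound 3 stands level with compound 2, the two together highest of the three, and compound 1 lies well under both. The next compound, compound 4 `COc1cccc(CNCCCNc2ccnc3cc(CC(C)C)ccc23)c1O`, is reached by isobutyl in place of 3-(dimethylamino)phenoxy on an aromatic carbon. Among the compounds with values here, the only measured step, no change at the digits printed from compound 2 to compound 3 (within the scatter), changed a substituent within the group that now leaves, so it bears only weakly on this change. Compound 1 also carries isobutyl and gives 23 10^-6 cm/s, but its amine side chain differs from that of compound 4, and no measurement separates the two changes. A fall beyond the scatter is expected, short of the full gap down to compound 1, with an estimated 3.2-fold lower number from compound 3 to compound 4 (0.50 log units; beyond the scatter). The estimate for compound 4 is 100 10^-6 cm/s, with an expected range of 30 10^-6 cm/s to 320 10^-6 cm/s.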

Compound 4, apparent permeability: 23 10^-6 cm/s
Compound 4: the middle estimate sits 4.3-fold (0.64 log units) above what was measured; the whole stated range lies above it.
By their numbers in this assay, from the lowest: compounds 1 and 4 (each within the scatter of the next); then compounds 2 and 3 (each within the scatter of the next).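

In this assay, isobutyl on this aromatic carbon gives the same large fall whichever phenoxy group leaves (a 14-fold lower number from compound 3 to compound 4 (1.14 log units; beyond the scatter); a 14-fold lower number from compound 2 to compound 4 (1.14 log units; beyond the scatter)). With isobutyl at this position, 2-hydroxy-3-methoxyphenyl in place of furan-2-yl leaves the number in place (no change at the digits printed from compound 1 to compound 4 (within the scatter)), so the low value of compound 1 can now be read against the isobutyl compound that carries the same side chain as compounds 2 and 3. Nothing measured here accounts for the fall.

Open, on these data alone, is whether the fall follows the loss of the aromatic ring or the arrival of isobutyl. An unsubstituted phenyl or a morpholine on this aromatic carbon would separate the two.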